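Swapping the acylurea aryl group in a thiazole hydrazone series

The source may report more compounds than this note shows. Statements on the series, on what has been measured and on what is new or still open speak of the compounds shown alone.

The set contains three measured compounds and one still to be tested. Compound 1 `Cc1nc(N(C)C(=O)NC(=O)c2c(F)cccc2F)sc1C(=O)N/N=C/c1ccc(C(F)(F)F)cc1` reaches only a limit in a functional assay on HepG2 cells (Homo sapiens) for inhibition, read by MTT assay, with a stated time of 72 h (a higher number here means a weaker inhibitor, a lower number a stronger inhibitor), reported as > 100 ug/mL. Compound 3 `CNc1nc(C(F)(F)F)c(C(=O)N/N=C/c2ccc(C(F)(F)F)cc2)s1` likewise gives only the limit > 100 ug/mL in this assay. For the measured compounds named here, compound 2 `CN(C(=O)NC(=O)c1cccc([N+](=O)[O-])c1)c1nc(C(F)(F)F)c(C(=O)N/N=C/c2ccccc2C(F)(F)F)s1` is the one member with a number: in this assay compound 2 gives 4.8 ug/mL, so it stands as the sole quantified value, the other two sitting at the limit of > 100 ug/mL in this assay, at which 2 of the 3 values shown sit.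

Compound 4 `CN(C(=O)NC(=O)c1c(Cl)cccc1Cl)c1nc(C(F)(F)F)c(C(=O)N/N=C/c2ccccc2C(F)(F)F)s1` differs from compound 2 in one place: 2,6-dichlorophenyl in place of 3-nitrophenyl on a carbonyl carbon. Going by the values given here, no measured pair differs by exactly this change, so the direction of the step can only be guessed. Compound 1, which also carries a 2,6-dihalophenyl on that carbonyl carbon, gives only a limit, but it differs from compound 2 in further places too, so it is not a clean guide.

The expected step from compound 2 to compound 4 is a moderate loss, a 3.1-fold higher number from compound 2 to compound 4 (0.49 log units; beyond the scatter), beyond the usual scatter. Compound 4 is therefore estimated at 15 ug/mL, with a range from 3 ug/mL to 80 ug/mL in this assay.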

Compound 4, half-maximal inhibitory concentration: 8.95 ug/mL
Beside the measured number, compound 4's estimate is 1.7-fold (0.22 log units) above it; the measured number falls inside the stated range.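

In this assay, replacing the 3-nitrophenyl on this carbonyl carbon with 2,6-dichlorophenyl gives a 1.9-fold higher number from compound 2 to compound 4 (0.27 log units; within the scatter), so the two groups cannot be told apart here. For the compounds shown here, the 3-nitrophenyl is therefore not the only group at this position that gives a measured value, and a nitro group is not required for one, as the 2,6-dichlorophenyl of compound 4 carries none. Compound 4 also stays off the limit of this assay, which is a limit and not a number: the limit of > 100 ug/mL in this assay, at which 2 of the 4 values shown sit.

Going by these compounds alone, compounds 1 and 3 each differ from compound 2 in more than one place, so no step to either can be read, and what separates the limits from the measured values remains unknown. Also open, from the compounds shown here alone, is how this position responds to an unsubstituted phenyl, a 3-aminophenyl or a 3-carboxyphenyl on the same carbonyl carbon.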